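A few compounds are considered here, and "the series" means these few. Any claim that something is new, unique, unknown or untested is made for them only; others in the source may bear on it.

Compound 1 `COc1ccc(/C=C(\C(=O)c2ccc(Br)cc2)S(=O)(=O)c2ccc(Br)cc2)c(F)c1` is tested in a functional assay on DU-145 cells (Homo sapiens) for inhibition, read by trypan blue exclusion, with a stated time of 96 h (a higher number here means a weaker inhibitor of growth, a lower number a stronger inhibitor of growth), where compound 1 gives 10000 nM. Among the three measured compounds it stands second highest. Its nearest neighbour is compound 3 `COc1ccc(/C=C(/Sc2ccc(Br)cc2)C(=O)c2ccc(Br)cc2)c(F)c1`, which in this assay gives 20000 nM; the step of a 2.0-fold higher number from compound 1 to compound 3 (0.30 log units; within the scatter) lies within the scatter. Furthest from compound 1 is compound 2 `O=C(O)c1ccc(C(=O)/C(=C\c2ccc(F)c([N+](=O)[O-])c2)SCc2ccc(F)cc2)cc1`, which in this assay gives 1000 nM, a gap beyond the scatter, though compound 2 differs from compound 1 in several places at once and no single step connects them.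

Compound 4 `COc1ccc(/C=C(\C(=O)c2ccc(Br)cc2)S(=O)(=O)c2ccc(Br)cc2)c(OC)c1` differs from compound 1 in one place: methoxy in place of fluoro on an aromatic carbon. For the measured compounds named here, none of the measured steps touches this position; the only single-point step, from compound 1 to compound 3, concerns a different part of the core and was within the scatter. There is therefore no basis in these data for expecting a change beyond the scatter in this assay. The step of no change at the digits printed from compound 1 to compound 4 (within the scatter) is accordingly expected to be small, and compound 4 is estimated at 10000 nM, with a range from 3000 nM to 30000 nM.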

Compound 4, concentration for 50% growth inhibition: 8000 nM
Beside the measured number, compound 4's estimate is 1.3-fold (0.10 log units) above it; the range from low to high includes it.
By their numbers in this assay, from the lowest: compound 2; then compounds 4, 1 and 3 (each within the scatter of the next, the first and the last beyond it).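

For the compounds shown here, the step at this aromatic carbon, a 1.3-fold lower number from compound 1 to compound 4 (0.10 log units; within the scatter) in this assay, is the first measured change at this position of the shared core. It shows that, ortho to a large group, this position accepts methoxy in place of fluoro without a change beyond the scatter, even though the entering group adds a hydrogen-bond acceptor that fluoro does not count. No measurement is available to explain this outcome, so the result stands only as an observation.

Going by these compounds, it remains open whether a different kind of group at this position, such as an amine, a hydroxyl group or a longer chain like butoxy, would produce a step beyond the scatter. On these data alone, it is also open whether the change from 2-fluoro-4-methoxyphenyl to 2,4-dimethoxyphenyl would give a similar step on the core of compound 3, which carries the sulfanyl link.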